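Shared-core series: bromo to trifluoromethyl on the aryl ring

The source may report more compounds than this note shows. Statements on the series, on what has been measured and on what is new or still open speak of the compounds shown alone.

Measured compounds:
compound 1, `O=C1CCC(Cc2ccc(I)cc2)C(=O)N1`, 87.2 mg/kg
compound 2, `O=C1CCC(Cc2ccc(Br)cc2)C(=O)N1`, 56.3 mg/kg

In a functional assay on the whole organism with Mus musculus as the target (on this read-out lower numbers stand for an effect already at smaller amounts and higher numbers for an effect only at larger amounts of compound), compound 1 gives 87.2 mg/kg. In this assay compound 2 gives 56.3 mg/kg. Going by the values given here, the single step between them, bromo in place of iodo on an aromatic carbon, is a 1.5-fold lower number from compound 1 to compound 2 (0.19 log units; within the scatter). Compound 2 therefore stands level with compound 1 within the scatter, and neither compound can be called the more active of the two.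

Compound 3 `O=C1CCC(Cc2ccc(C(F)(F)F)cc2)C(=O)N1` differs from compound 2 by trifluoromethyl in place of bromo on an aromatic carbon. Among the compounds with values here, the only measured step exchanges one halogen for another and stays within the scatter; no measured step puts a trifluoromethyl group in place of a halogen, so the expectation rests on that one comparison alone. Given the step from compound 1 to compound 2 of a 1.5-fold lower number from compound 1 to compound 2 (0.19 log units; within the scatter), the expected change for compound 3 is a 1.1-fold higher number from compound 2 to compound 3 (0.03 log units; within the scatter), that is, no step beyond the scatter in either direction. Compound 3 is estimated at 60 mg/kg in this assay, with an expected range from 30 mg/kg to 120 mg/kg.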

Compound 3, dose for half-maximal effect: 119 mg/kg
For compound 3 the middle estimate is 2.0-fold (0.30 log units) below the measured one; the measured number falls inside the stated range.
By their numbers in this assay, from the lowest: compounds 2, 1 and 3 (each within the scatter of the next, the first and the last beyond it).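

In this assay, going by these compounds alone, the exchange of bromo for trifluoromethyl on this aromatic carbon gives the first step beyond the scatter, a 2.1-fold higher number from compound 2 to compound 3 (0.33 log units; beyond the scatter), so the position is not wholly indifferent to the group it carries, although the step is only modest. The exchange of iodo for trifluoromethyl on the same carbon, a 1.4-fold higher number from compound 1 to compound 3 (0.14 log units; within the scatter), stays within the scatter, so only bromo and trifluoromethyl are separated here, while iodo stands level with both and the three groups form no clean ladder. Nothing at hand bears on why bromo and trifluoromethyl part in this way.

As far as these compounds go, how this position responds to a group of another kind stays open: a methoxy group, an amine or a carboxylic acid on this aromatic carbon would reach well beyond the halogens and trifluoromethyl. Also open, from the compounds shown here alone, are how chloro, fluoro or plain hydrogen on this carbon compare with bromo in this assay, and whether the gap between bromo and trifluoromethyl persists when the shared core is changed elsewhere.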